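From Compound 3 to Compound 4: Liver Extraction Outlook

This account rests on a few compounds, and the source may have more. Where it says the series, first, only, none or still open, it means among the compounds named here.

This small set shares one core and differs in the aromatic groups attached to it; the question is how large a share of each compound the liver removes in one pass. In an ADME assay on S9 fraction from liver (Mus musculus) for metabolic stability, read by LC-MS, using NADPH, with a stated time of 45 min, tested at 3 uM, in the presence of a further agent that is not named here (a higher number here means that the liver removes a larger share of the compound in one pass, a lower number that the liver removes a smaller share), compound 1 `COc1ccc(-n2cnc3cnc(Nc4cccc(NC(C)=O)c4)cc32)cc1OC` gives 1, and in this assay compound 2 `CCOc1ccc(-n2cnc3cnc(-c4ccc(F)cc4C)cc32)cc1` gives 0.97. Both values sit at the top of the scale, so the liver strips away nearly all of either compound in a single pass. Going by the values given here, compound 3 `Cc1cccc(C)c1-c1cc2c(cn1)ncn2-c1ccc(OC(F)F)cc1` stands in this assay with the entry "not determined" (no result reported), so its position on this scale is unknown and no step starting from it can be computed. Compound 4 `Cc1cc(F)c(F)cc1-c1cc2c(cn1)ncn2-c1ccc(OC(F)F)cc1` differs from compound 3 in one place: 4,5-difluoro-2-methylphenyl in place of 2,6-dimethylphenyl on an aromatic carbon. Whether this change would raise or lower the read-out cannot be judged from compound 3 alone. Compound 1 gives 1 and compound 2 gives 0.97 in this assay, and these two results are the only footing for an expectation. Compound 4 is therefore expected to give about 0.9 in this assay, within a range from 0.7 to 1.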

Compound 4, hepatic extraction ratio: 0.15
The estimate for compound 4 lay 0.75 above the measured number, and the stated range ends above it.
By their numbers in this assay, from the lowest: compound 4; then compounds 2 and 1 (each within the scatter of the next).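

Going by these compounds alone, compound 4 gives 0.15, but compound 3 has no number to set against it, so no step between them can be read. The compounds shown leave open whether the 4,5-difluoro-2-methylphenyl group accounts for that low value, and no available evidence bears on a cause.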